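Capping the Hydroxyl: From Compound 3 to Compound 4

The source may report more compounds than this note shows. Statements on the series, on what has been measured and on what is new or still open speak of the compounds shown alone.

Compound 1 `N#Cc1cnc(NCc2cnccc2C(F)(F)F)cc1N[C@H]1C[C@H](O)C1`: > 10000 nM
Compound 2 `N#Cc1cnc(NCc2cnccc2C(F)(F)F)cc1N[C@H]1CC[C@@H](O)CC1`: 4500 nM
Compound 3 `N#Cc1cnc(NCc2cnccc2C(F)(F)F)cc1NC[C@H]1CC[C@@H](O)CC1`: 500 nM

In an assay on isolated protein for inhibition of protein kinase C delta type (Homo sapiens), read by TR-FRET, with a stated time of 2 h (on this read-out higher numbers stand for weaker inhibition and lower numbers for stronger inhibition), compound 3 gives 500 nM, the lowest number shown, so it is the strongest inhibitor of the three. Compound 2 gives 4500 nM. For compound 1 the value is only a limit of the assay, > 10000 nM (the limit of > 10000 nM in this assay, at which 1 of the 3 values shown sits). The measured steps concern ring size and linker: a 9.0-fold lower number from compound 2 to compound 3 (0.95 log units; beyond the scatter) and an at least 2.2-fold lower number from compound 1 to compound 2 (0.34 log units; beyond the scatter). Compound 4 `CO[C@H]1CC[C@H](CNc2cc(NCc3cnccc3C(F)(F)F)ncc2C#N)CC1` differs from compound 3 in another way: 4-methoxycyclohexyl in place of 4-hydroxycyclohexyl on a saturated chain carbon bound to a nitrogen on an aromatic ring. For the measured compounds named here, no measured step alters the hydroxyl, so there is no direct guide; a hydrogen-bond donor is lost while the acceptor stays. A small to modest weakening is expected, and compound 4 is estimated at 1000 nM (range 300 nM to 3500 nM), which is expected to mean a 2.0-fold higher number from compound 3 to compound 4 (0.30 log units; within the scatter).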

Compound 4, half-maximal inhibitory concentration: > 10000 nM
Compound 4 ended at the assay's limit (the forecaster's own chance of this, stated with the estimate: 5%); middle value at least 10-fold (1.00 log units) away from the limit.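

Of the changes shown, this is the first to touch the hydroxyl itself, and this one small change on the ring has a large effect: an at least 20-fold higher number from compound 3 to compound 4 (1.30 log units; beyond the scatter). The benefit of the longer linker in compound 3 does not survive the change either, with an at least 2.2-fold higher number from compound 2 to compound 4 (0.34 log units; beyond the scatter). Compound 4 gives only a limit of the assay, not a number, so its step from compound 1 cannot be read: the limit of > 10000 nM in this assay, at which 2 of the 4 values shown sit.

On these data alone, the true value of compound 4 stays open. So does whether an amine or a carboxylic acid in place of the hydroxyl would keep the number near that of compound 3.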